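Nitro in place of methyl on the pendant aryl of compound 2

The source may hold more compounds than are shown below. What is called first, only, known or untested is meant among the compounds shown, and "the series" means these compounds.

Compound 1 `Cc1ccc(-c2ccc(C)n2-c2ccc(-c3nc4ccccc4s3)cc2)cc1`: 17800 nM
Compound 2 `Cc1ccc(-c2ccc(C)n2-c2ccc(-c3nc4ccc(F)cc4s3)cc2)cc1`: 16700 nM

Among the measured compounds shown here, in a functional assay on MDA-MB-231 cells (Homo sapiens) for cytotoxicity, read by MTT assay, with a stated time of 72 h (a higher number here means a weaker inhibitor, a lower number a stronger inhibitor), compound 2 gives 16700 nM, and the only step on record, a 1.1-fold lower number from compound 1 to compound 2 (0.03 log units; within the scatter), lies within the scatter, so compound 1 and compound 2 stand together. Compound 3 `Cc1ccc(-c2ccc([N+](=O)[O-])cc2)n1-c1ccc(-c2nc3ccc(F)cc3s2)cc1` differs from compound 2 by nitro in place of methyl on an aromatic carbon. For the measured compounds named here, no measured step touches this ring; the one step seen, a 1.1-fold lower number from compound 1 to compound 2 (0.03 log units; within the scatter), changed the other end of the molecule and shows only a flat pair. Compound 3 is therefore expected to move little, the estimated step being a 1.2-fold lower number from compound 2 to compound 3 (0.08 log units; within the scatter). For compound 3 the expected value is 14000 nM, with a range from 5000 nM to 40000 nM.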

Compound 3, half-maximal inhibitory concentration: 17000 nM
Beside the measured number, compound 3's estimate is 1.2-fold (0.08 log units) below it; the measured number falls inside the stated range.
By their numbers in this assay, from the lowest: compounds 2, 3 and 1 (each within the scatter of the next).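

In this assay, among the compounds shown here, 4-methylphenyl to 4-nitrophenyl gives a 1.0-fold higher number from compound 2 to compound 3 (0.01 log units; within the scatter) and is the first measured step at this position, para to a large group. Exchanging methyl for nitro, which brings in two hydrogen-bond acceptors, leaves compound 3 within the scatter of compound 2, so this position tolerates the change in this read-out. Nothing on hand explains this flat step.

All steps shown so far lie within the scatter. From the compounds shown here alone, whether an amine, a carboxylic acid or a longer chain in the same place would move the number remains open.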